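From Isopropyl to Methoxy: One Swap, One Expectation

A few compounds are considered here, and "the series" means these few. Any claim that something is new, unique, unknown or untested is made for them only; others in the source may bear on it.

Compound 1, `COc1ccc(-c2cc(=O)c3cc(C(=O)O)ccc3o2)cc1`: 13%
Compound 2, `COc1c(-c2ccc(C(C)C)cc2)oc2ccc(C(=O)O)cc2c1=O`: 18%

Both numbers come from a functional assay on the whole organism (stomach) for inhibition, with Rattus norvegicus as the target, at a dose of 80 mg/kg; on this read-out lower numbers stand for less inhibition and higher numbers for more inhibition at the one dose given (going by the name of the read-out). Compound 2 gives 18% and compound 1 gives 13%; the gap between them lies within the usual scatter, so the two numbers count as level. Compound 3, `COc1ccc(-c2oc3ccc(C(=O)O)cc3c(=O)c2OC)cc1`, differs from compound 2 in one place: methoxy in place of isopropyl on an aromatic carbon. Going by the values given here, no measured pair shows what this swap does in this assay. Compound 1 gives 13%, so little movement beyond the scatter is expected. The step from compound 2 to compound 3 is estimated at a number 3 percentage points lower from compound 2 to compound 3 (within the scatter). Compound 3 is expected to give about 15%, within 5% to 30%.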

Compound 3, a percentage reported as inhibition, in the whole organism at one dose (the size of the read-out at that dose, not a potency): 22%
For compound 3 the middle estimate is 7 percentage points below the measured one, within the range that was stated.
By their numbers in this assay, from the lowest: compounds 1, 2 and 3 (each within the scatter of the next).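

In this assay, methoxy in place of isopropyl on an aromatic carbon gives a number 4 percentage points higher from compound 2 to compound 3 (within the scatter) and so leaves the two groups level at this position, para to a large group. Methoxy in place of hydrogen on an aromatic carbon, a change at another place, gives a number 9 percentage points higher from compound 1 to compound 3 (within the scatter) and also stays level. No measurement at hand gives a reason for these results. On these data alone, whether an amine or a longer chain at the para position would move the number beyond the scatter remains open. So does the effect of other doses.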